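The source may report more compounds than this note shows. Statements on the series, on what has been measured and on what is new or still open speak of the compounds shown alone.

Values in an ADME assay on cells (Hepatocyte, Homo sapiens) for metabolic stability, read by LC-MS, with a stated time of 60 min, tested at 1 uM; a lower number here means slower removal, a higher number faster removal of the compound:

Compound 1, `COc1cc(N(CC2CC2)c2ccccc2)cnc1C(=O)[C@H]1C[C@@H]1C(=O)O`: compound 1 gives 3 uL/min
Compound 2, `COc1cc(N(CC2CC2)c2cc(C(F)(F)F)ccc2F)cnc1C(=O)[C@H]1C[C@@H]1C(=O)O`: compound 2 gives < 1.1 uL/min, a limit of the assay and not a number
Compound 3, `COc1cc(N(CC2CC2)c2cc(Cl)ccc2F)cnc1C(=O)[C@H]1C[C@@H]1C(=O)O`: compound 3 gives 1.3 uL/min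

Compound 3 holds the lowest of the two numbers shown; its nearest neighbour by number is compound 1, and the step of a 2.3-fold lower number from compound 1 to compound 3 (0.36 log units; beyond the scatter) lies beyond the scatter. The step of an at least 1.1-fold higher number from compound 2 to compound 3 (0.07 log units; that floor lies within the scatter) rests on a floor, (the limit of < 1.1 uL/min in this assay, at which 1 of the 3 values shown sits), and that floor sits within the scatter, so compound 2 and compound 3 cannot be placed in order.

Compound 4, `COc1cc(N(CC2CC2)c2cc(Cl)c(F)cc2F)cnc1C(=O)[C@H]1C[C@@H]1C(=O)O`, is not yet measured. The change from compound 3 is fluoro in place of hydrogen on an aromatic carbon.

For the measured compounds named here, two measured steps bear on this. The replacement of phenyl by 5-chloro-2-fluorophenyl, a 2.3-fold lower number from compound 1 to compound 3 (0.36 log units; beyond the scatter), lowered the number in this assay modestly. The exchange of trifluoromethyl for chloro, an at least 1.1-fold higher number from compound 2 to compound 3 (0.07 log units; that floor lies within the scatter), produced nothing beyond the scatter. Adding a further fluoro to the same aryl ring is a smaller change than the first of these and is expected to give at most a small step downward, or none beyond the scatter, in this assay; the expected step is a 1.3-fold lower number from compound 3 to compound 4 (0.11 log units; within the scatter). With compound 3 already near the floor, compound 4 may well return only a limit. Compound 4 is therefore estimated at 1 uL/min, within 0.5 uL/min to 2.2 uL/min.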

Compound 4, intrinsic clearance in a liver preparation (reported as CLH), per the amount of preparation that the assay uses in the Hepatocyte assay: < 1.5 uL/min
Compound 4: no number, only a limit; the forecaster's own chance of this, stated with the estimate: 45%; the middle value does not contradict the limit.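

In the Hepatocyte assay, compound 4 gives only a limit and not a number: the limit of < 1.5 uL/min in the Hepatocyte assay, at which 1 of the 4 values shown sits. In the Hepatocyte assay the step from compound 3 to compound 4 cannot be read, and an at least 2.0-fold lower number from compound 1 to compound 4 (0.30 log units; that floor lies within the scatter) rests on a floor within the scatter, so the 5-chloro-2,4-difluorophenyl group cannot be placed in order against phenyl on this read-out. What is new at this ring carbon, ortho to the chloro group and para to a large group, comes from a physicochemical assay for lipophilicity, read by LC-MS, in phosphate buffer, measured as octanol-water partition, at pH 7.4 (on this read-out higher numbers stand for higher lipophilicity and lower numbers for lower lipophilicity), where compound 3 gives 1.1 and compound 4 gives 1.1, which is no change at the digits printed from compound 3 to compound 4 (within the scatter): on the distribution coefficient, fluoro in place of hydrogen here shows nothing.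

Whether this fluoro changes the rate of removal at all stays open, since the compounds shown with this aryl ring give either a low number or a limit in the Hepatocyte assay. Also open, on these data alone, is whether a nitrile or an amine on the same ring carbon would move either read-out, which the hydrogen and fluoro pair alone cannot tell.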